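Swapping a ring for an open chain

This account rests on a few compounds, and the source may have more. Where it says the series, first, only, none or still open, it means among the compounds named here.

In a functional assay on G-361 cells (Homo sapiens) for cytotoxicity, read by MTT assay, with a stated time of 3 days (on this read-out higher numbers stand for weaker inhibition and lower numbers for stronger inhibition), compound 2 `N#Cc1c(Nc2nccs2)nc(SCc2nc3ccccc3[nH]2)nc1-c1ccccc1` reads 11.9 nM and compound 1 `N#Cc1c(Nc2ccccn2)nc(SCc2nc3ccccc3[nH]2)nc1-c1ccccc1` reads 8.9 nM on the shared core, so the two stand level within the scatter. Compound 3 `N#Cc1c(NNC(N)=S)nc(SCc2nc3ccccc3[nH]2)nc1-c1ccccc1` keeps that core and differs from compound 2 at one place, on a nitrogen on an aromatic ring. The change is a group of 4 heavy atoms (1 carbon, 2 nitrogen, 1 sulfur; no ring) in place of a group of 5 heavy atoms (3 carbon, 1 nitrogen, 1 sulfur; one five-membered aromatic ring with 2 hetero atoms), on a nitrogen on an aromatic ring and it leaves no ring on that nitrogen.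

Among the measured compounds shown here, only one measured step bears on this place. It is a 1.3-fold higher number from compound 1 to compound 2 (0.13 log units; within the scatter) and it exchanged one aromatic ring for another, which left the number inside the scatter. For the measured compounds named here, no measured compound lacks a ring on that nitrogen, so this step is only a weak guide to what an open group will do. The data therefore give no firm direction, and a modest move toward weaker inhibition is a cautious guess with wide margins. The expected change is a 2.1-fold higher number from compound 2 to compound 3 (0.32 log units; beyond the scatter) in this assay and it could well turn out smaller. Compound 3 is therefore estimated at 25 nM (expected range 5 nM to 120 nM).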

Compound 3, half-maximal inhibitory concentration: 3.96 nM
Compound 3: middle estimate off by 6.3-fold (0.80 log units), on the high side, and the stated range ends above it.
By their numbers in this assay, from the lowest: compound 3; then compounds 1 and 2 (each within the scatter of the next).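

In this assay the open group gives a 3.0-fold lower number from compound 2 to compound 3 (0.48 log units; beyond the scatter) and also a 2.2-fold lower number from compound 1 to compound 3 (0.35 log units; beyond the scatter); both steps lie beyond the scatter and point the same way. The ring-for-ring step could not show this: among these three compounds, an aromatic ring on this nitrogen is not needed for a low number, and the group without a ring gives the lowest number of the set. The data here offer no measurement that explains why the number falls.

The entering group differs from both rings in several ways at once, since it has no ring, has a double bond outside aromatic rings and has 2 hydrogen-bond donors, so these compounds leave open which of these features goes with the lower number. Going by these compounds, a simple amine on that nitrogen, or the same open chain with a carbonyl oxygen in place of its sulfur, would help to separate those features, and it also remains open whether the lower number would hold in other cell lines.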